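Plasma protein binding: chloro in place of cyclobutylmethoxy

The compounds below may be only part of what the source reports. "The series", "measured", "known", "first", "only" and "open" are said of these compounds alone.

Measured so far in an ADME assay on a cell-free system (plasma, Homo sapiens) for protein binding (all three numeric)
- compound 1 `C[C@@H](Oc1cc2cnn(CCC(=O)O)c2cc1Cl)c1ccccn1` gives 90.1%
- compound 2 `COCCOc1cc2oc(=O)n(CCC(=O)O)c2cc1Cl` gives 70.7%
- compound 3 `O=C(O)CCn1c(=O)oc2cc(OCC3CCC3)c(Cl)cc21` gives 98.1%

Compound 3 (98.1%) has the lowest unbound fraction of the three. Compound 1 (90.1%) lies nearest to it and compound 2 (70.7%) furthest, both beyond the scatter.

Compound 4 `O=C(O)CCn1c(=O)oc2cc(Cl)c(Cl)cc21` is not yet measured. It has chloro in place of cyclobutylmethoxy on an aromatic carbon, ortho to a chloro group (chloro in place of cyclobutylmethoxy on an aromatic carbon).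

One measured step changes the same substituent, with cyclobutyl in place of methoxymethyl, and it was large (a 15-fold lower unbound fraction from compound 2 to compound 3 (1.19 log units; beyond the scatter)). Going by the values given here, no measured compound carries chloro at this place, so that step guides size only. Compound 3 (98.1%) sits at the low end of the unbound range, so the expected direction is upward, by less than the measured step. The expected move is a 5.3-fold higher unbound fraction from compound 3 to compound 4 (0.72 log units; beyond the scatter) in this assay as an estimate. Compound 4 is estimated at 90% (expected range 78% to 96%).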

Compound 4, plasma protein binding: 98.2%
For compound 4 the middle estimate is 5.6-fold (0.74 log units) (unbound fraction) above the measured one, outside the stated range (above it).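

In this assay chloro on this aromatic carbon, ortho to a chloro group, gives a 1.1-fold lower unbound fraction from compound 3 to compound 4 (0.02 log units; within the scatter) and so a substituent of 1 heavy atom cannot be told apart from cyclobutylmethoxy with its 6 heavy atoms and four-membered ring. Set against 2-methoxyethoxy, the same chloro gives a 16-fold lower unbound fraction from compound 2 to compound 4 (1.21 log units; beyond the scatter) and this matches the earlier finding of a 15-fold lower unbound fraction from compound 2 to compound 3 (1.19 log units; beyond the scatter) in showing a large step from compound 2. Among these three compounds only compound 2 stands apart, and heavy-atom count alone does not order the substituents at this place.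

On these data alone, how an amine or a longer ether chain ending in a hydroxyl group would read at this aromatic carbon remains open. No measurement at hand explains why chloro and cyclobutylmethoxy read alike here.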